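Removing Iodine from the Benzyl Group: Expected Tolerance

The source may hold more compounds than are shown below. What is called first, only, known or untested is meant among the compounds shown, and "the series" means these compounds.

This set of three measured compounds shares one core and differs only in the group carried on the saturated chain carbon bound to an aromatic nitrogen. In an ADME assay on MDBK cells (Bos taurus) for cytotoxicity (a lower number here means that less compound is tolerated, a higher number that more compound is tolerated), compound 1 `c1ccc(Cn2ccc3nc(-c4ccccc4)nc-3c2)cc1` reaches only the limit of the assay, > 100000 nM, and no number. Compound 2 `Cc1ccccc1Cn1ccc2nc(-c3ccccc3)nc-2c1` likewise reaches only the limit, > 100000 nM. Among the compounds with values here, compound 3 `Ic1ccc(Cn2ccc3nc(-c4ccccc4)nc-3c2)cc1` is the single compound with a number, giving 22000 nM in this assay. The other two values are limits, as noted in the limit of > 100000 nM in this assay, at which 2 of the 3 values shown sit. The steps to compound 3 are therefore readable: an at least 4.5-fold lower number from compound 1 to compound 3 (0.65 log units; beyond the scatter) and an at least 4.5-fold lower number from compound 2 to compound 3 (0.65 log units; beyond the scatter), both at least modest, while a step that the two limits leave unreadable from compound 1 to compound 2 cannot be sized.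

Compound 4 `c1ccc(-c2nc3ccn(Cc4ccncc4)cc-3n2)cc1` is not yet measured. It differs from compound 3 by pyridin-4-yl in place of 4-iodophenyl on a saturated chain carbon bound to an aromatic nitrogen. Both readable steps point to the iodo-bearing group as what set compound 3 apart, so taking that group away is expected to undo much of that step. The estimate for compound 4 in this assay is 80000 nM, with a range from 20000 nM to 250000 nM; this estimate corresponds to a 3.6-fold higher number from compound 3 to compound 4 (0.56 log units; beyond the scatter), and there is a real chance that only a limit is returned.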

Compound 4, half-maximal cytotoxic concentration: > 100000 nM
Compound 4 was reported as a limit (the forecaster's own chance of this, stated with the estimate: 50%); middle value at least 1.2-fold (0.09 log units) away from the limit.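

In this assay, within the data shown here, pyridin-4-yl in place of 4-iodophenyl gives an at least 4.5-fold higher number from compound 3 to compound 4 (0.65 log units; beyond the scatter), which is the first readable step at this place that leads away from compound 3 to a group with a hetero atom in its ring. The earlier compounds without iodine carried rings of carbon only, so a ring holding a nitrogen and a hydrogen-bond acceptor now joins them, and among these four compounds the 4-iodophenyl group of compound 3 is the only one that gives a number, with no compound going against this. The steps among compound 1, compound 2 and compound 4 cannot be read, so these three cannot be ranked, because all of them sit at one limit: the limit of > 100000 nM in this assay, at which 3 of the 4 values shown sit.

Whether the iodine itself matters, or any larger group at this place would do the same, stays open, since chloro or bromo in place of iodo, or an amine or a carboxylic acid on the same ring, do not appear among these compounds. From the compounds shown here alone, it also stays open how much compound would be tolerated for compound 1, compound 2 and compound 4 if the assay went beyond its limit.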